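Chain-terminus variation and its effect on cytotoxicity

This account rests on a few compounds, and the source may have more. Where it says the series, first, only, none or still open, it means among the compounds named here.

Three compounds share a core and differ only in the group on a saturated chain carbon two bonds along the chain from a sulfur. Compound 1 `N#CCCSC(=S)NCc1cccnc1` carries a cyano group there, and in a functional assay on SK-BR-3 cells (Homo sapiens) for cytotoxicity, read by resazurin assay, with a stated time of 72 h (a lower number here means a stronger inhibitor, a higher number a weaker inhibitor), compound 1 gives 2840 nM. Compound 2 `OCCCSC(=S)NCc1cccnc1`, with hydroxymethyl, gives 1320 nM in this assay; compound 3 `NC(=O)CCSC(=S)NCc1cccnc1`, with carbamoyl, gives 1160 nM. The steps of a 2.2-fold lower number from compound 1 to compound 2 (0.33 log units; beyond the scatter) and a 2.4-fold lower number from compound 1 to compound 3 (0.39 log units; beyond the scatter) are modest, while a 1.1-fold lower number from compound 2 to compound 3 (0.06 log units; within the scatter) lies within the scatter. Among the three, compound 3 is separated beyond the scatter only from compound 1; compound 2 sits within the scatter of it.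

Compound 4 `O=S(=O)(O)CCCSC(=S)NCc1cccnc1` differs from compound 3 in one place: sulfomethyl in place of carbamoyl on a saturated chain carbon, two bonds along the chain from a sulfur. Going by the values given here, no measured step covers a sulfomethyl group. The two steps that moved the number both concern exchange of the cyano group, and the exchange between hydroxymethyl and carbamoyl left the number unchanged within the scatter. On that basis the expected step is a 1.4-fold higher number from compound 3 to compound 4 (0.14 log units; within the scatter) in this assay, with wide uncertainty. Compound 4 is estimated at 1600 nM in this assay, with a range from 600 nM to 5000 nM.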

Compound 4, half-maximal inhibitory concentration: 6770 nM
The estimate for compound 4 lay 4.2-fold (0.63 log units) below the measured number; the measured number lies above the stated range.
By their numbers in this assay, from the lowest: compounds 3 and 2 (each within the scatter of the next); then compound 1; then compound 4.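

Unlike the exchange between hydroxymethyl and carbamoyl, the move to the sulfo-bearing chain is not neutral at this position: this assay shows a 5.8-fold higher number from compound 3 to compound 4 (0.77 log units; beyond the scatter) and, on the same chain, a 5.1-fold higher number from compound 2 to compound 4 (0.71 log units; beyond the scatter) beyond the scatter. All earlier steps lowered the number on leaving cyano, whereas sulfomethyl goes the other way, with a 2.4-fold higher number from compound 1 to compound 4 (0.38 log units; beyond the scatter) so that cyano no longer marks the high end of the series. The position therefore tolerates hydroxymethyl and carbamoyl alike, but that equivalence does not extend to every terminal group.

Nothing available bears on why the number rises with this change. On these data alone, whether a carboxylic acid, a sulfonamide or an amine at the chain end would track compound 4 or stay with compound 2 and compound 3 remains open, as does the effect of a longer chain.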